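The source may hold more compounds than are shown below. What is called first, only, known or untested is meant among the compounds shown, and "the series" means these compounds.

Compound 1 `Cc1c(Cc2ccccc2)c(NNC(=O)Nc2cc(Cl)nc(Cl)c2)nc2c1cnn2C` gives 21400 nM. Compound 2 `Cn1ncc2c(-c3ccccc3)cc(NNC(=O)Nc3cc(Cl)nc(Cl)c3)nc21` gives 76900 nM. Compound 3 `Cc1nn(C)c2nc(NNC(=O)Nc3cc(Cl)nc(Cl)c3)cc(-c3ccc(Cl)s3)c12` gives 29400 nM.

All three numbers come from a functional assay on SW620/5-FU cells (Homo sapiens) for cytotoxicity, read by MTT assay, with a stated time of 48 h, in the presence of a further agent that is not named here; on this read-out higher numbers stand for an effect only at larger amounts of compound and lower numbers for an effect already at smaller amounts. Compound 3 stands second highest of the three. Its number and that of compound 1 lie within the usual scatter of each other, so the two cannot be told apart, while the number of compound 2 lies beyond the scatter and is the higher one. Compound 4 `Cc1nn(C)c2nc(NNC(=O)Nc3cc(Cl)nc(Cl)c3)cc(-c3ccc(F)cc3)c12` has not been measured. It differs from compound 3 in one place: 4-fluorophenyl in place of 5-chlorothiophen-2-yl on an aromatic carbon. Going by the values given here, no measured pair shows what a change of this kind does here, so no step beyond the scatter is expected in either direction. Compound 4 is therefore expected to give about 30000 nM, within a range from 12000 nM to 75000 nM. The expected step of a 1.0-fold higher number from compound 3 to compound 4 (0.01 log units; within the scatter) stays within the scatter.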

Compound 4, half-maximal effective concentration: 17400 nM
Beside the measured number, compound 4's estimate is 1.7-fold (0.24 log units) above it, within the range that was stated.
By their numbers in this assay, from the lowest: compounds 4, 1 and 3 (each within the scatter of the next); then compound 2.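

Putting 4-fluorophenyl in place of 5-chlorothiophen-2-yl on this aromatic carbon gives a 1.7-fold lower number from compound 3 to compound 4 (0.23 log units; within the scatter) in this assay, so the two compounds cannot be told apart. At this position, then, a six-membered aromatic ring of carbon only and a five-membered aromatic ring with a hetero atom give numbers within the scatter of each other. No supporting measurement bears on this result. Going by these compounds, whether an amine or a carboxylic acid on this aromatic carbon would move the number beyond the scatter stays open.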